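The source may hold more compounds than are shown below. What is called first, only, known or untested is meant among the compounds shown, and "the series" means these compounds.

Measured so far:
compound 1 `CCc1c(Cl)cc2[nH]c(=O)c(=O)[nH]c2c1N(CCO)S(C)(=O)=O`, in a physicochemical assay for solubility (on this read-out lower numbers stand for lower solubility and higher numbers for higher solubility), compound 1 gives 72 ug/mL
compound 2 `CS(=O)(=O)N(CCCO)c1c(Cl)c(Cl)cc2[nH]c(=O)c(=O)[nH]c12`, in this assay compound 2 gives 76 ug/mL
compound 3 `Cc1cc2[nH]c(=O)c(=O)[nH]c2c(N(CCO)S(C)(=O)=O)c1Cl`, in this assay compound 3 gives 70 ug/mL

The three compounds share one core and differ only in the substituents around it and in the chain on the sulfonamide nitrogen. In this assay compound 3 stands within the usual scatter of both compound 1 and compound 2, so the three numbers cannot be told apart; nothing in them separates one compound from another.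

Compound 4 `Cc1cc2[nH]c(=O)c(=O)[nH]c2c(N(CC(=O)O)S(C)(=O)=O)c1Cl` has not been measured. It differs from compound 3 in a single place: carboxy in place of hydroxymethyl on a saturated chain carbon bound to a sulfonamide nitrogen. Seen one bond further out, the chain on the sulfonamide nitrogen goes from 2-hydroxyethyl to carboxymethyl. For the measured compounds named here, no two measured compounds differ in this way, so there is no measured step of this kind to lean on, and the three measured numbers, all alike, give no trend either.

With that in mind, the account expects for compound 4 a modest rise in this assay, close to the edge of the scatter rather than clearly beyond it, a step of a 1.7-fold higher number from compound 3 to compound 4 (0.23 log units; within the scatter). The estimate for compound 4 is 120 ug/mL, with a range from 40 ug/mL to 350 ug/mL.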

Compound 4, solubility: 72 ug/mL
Beside the measured number, compound 4's estimate is 1.7-fold (0.22 log units) above it; the range from low to high includes it.
By their numbers in this assay, from the lowest: compounds 3, 1, 4 and 2 (each within the scatter of the next).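

In this assay, putting carboxy in place of hydroxymethyl on a saturated chain carbon bound to a sulfonamide nitrogen gives a 1.0-fold higher number from compound 3 to compound 4 (0.01 log units; within the scatter). For the compounds shown here, this is the first single-place step available, where the earlier compounds differed in more than one place and could offer only three similar numbers. On this read-out, compounds carrying 2-hydroxyethyl and carboxymethyl at this position cannot be told apart, and no measurement at hand accounts for that.

On these data alone, whether an amine, a primary amide or a longer chain ending in carboxy would also leave the number within the scatter remains open. So does whether the same exchange would read alike on the substituent pattern of compound 1 or compound 2.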